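This account rests on a few compounds, and the source may have more. Where it says the series, first, only, none or still open, it means among the compounds named here.

In a functional assay on SiHa cells (Homo sapiens) for cytotoxicity, read by MTT assay, with a stated time of 48 h (on this read-out lower numbers stand for stronger inhibition and higher numbers for weaker inhibition), compound 3 `CCCCCCCCCCCCCCCCCCNC(=O)[C@@H](NS(=O)(=O)c1ccc(C)cc1)[C@@H](C)O` gives 29800 nM, the second highest of the three numbers measured. Compound 1 `CCCCCCCCCCCCCCCCCCNC(=O)[C@@H](NC(=O)c1ccco1)[C@@H](C)O` gives 13400 nM, and compound 2 `CCCCCCCCCCCCCCCCCCNC(=O)[C@@H](NC(=O)c1cc2ccccc2n1C)[C@@H](C)O` gives 113000 nM. Compound 4 `CCCCCCCCCCCCCCCCCCNC(=O)[C@@H](NS(=O)(=O)c1cccs1)[C@@H](C)O` differs from compound 3 by thiophen-2-yl in place of 4-methylphenyl on a sulfonyl sulfur. For the measured compounds named here, no measured step alters only the ring on the sulfonyl sulfur; the nearest steps replace the whole group on the amine nitrogen, with a 2.2-fold higher number from compound 1 to compound 3 (0.35 log units; beyond the scatter) and a 3.8-fold lower number from compound 2 to compound 3 (0.58 log units; beyond the scatter), both modest. Because a 3.8-fold lower number from compound 2 to compound 3 (0.58 log units; beyond the scatter) moved the number only modestly, compound 4 is expected to sit close to compound 3, with a step of a 1.2-fold lower number from compound 3 to compound 4 (0.08 log units; within the scatter) that may not pass the scatter. Compound 4 is therefore estimated at 25000 nM, within a range from 9000 nM to 70000 nM.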

Compound 4, half-maximal inhibitory concentration: > 200000 nM
Compound 4: no number, only a limit; the forecaster's own chance of this, stated with the estimate: 5%; middle value at least 8.0-fold (0.90 log units) away from the limit.
By their numbers in this assay, from the lowest: compound 1; then compound 3; then compound 2. At a limit, above all of these: compound 4.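

In this assay compound 4 gives > 200000 nM, which is a limit of the assay and not a number. For the compounds shown here, the ring on the sulfonyl sulfur counts on its own: thiophen-2-yl in place of 4-methylphenyl gives an at least 6.7-fold higher number from compound 3 to compound 4 (0.82 log units; beyond the scatter), whereas the earlier steps only replaced the whole group on the amine nitrogen. The whole-group steps read as an at least 14-fold higher number from compound 1 to compound 4 (1.17 log units; beyond the scatter), a large step, and an at least 1.7-fold higher number from compound 2 to compound 4 (0.24 log units; that floor lies within the scatter), whose floor does not clearly separate the pair.

As far as these compounds go, the true size of all three steps stays open. Also open, from the compounds shown here alone, is how a plain phenyl or a furan-2-yl ring on the sulfonyl sulfur would read.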